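The source may report more compounds than this note shows. Statements on the series, on what has been measured and on what is new or still open speak of the compounds shown alone.

Three compounds measured in a functional assay on DU-145 cells (Homo sapiens) for inhibition, read by trypan blue exclusion, with a stated time of 96 h (on this read-out lower numbers stand for stronger inhibition of growth and higher numbers for weaker inhibition of growth), share a chlorophenyl ketone bearing a sulfur-linked fluorobenzyl group, and differ in the oxygen substitution of the second aryl ring and in the oxidation state of the sulfur. Compound 3 `CCOc1ccc(/C=C(/SCc2ccc(F)cc2)C(=O)c2ccc(Cl)cc2)cc1OC` gives 1000 nM. Compound 1 `CCOc1ccc(/C=C(\C(=O)c2ccc(Cl)cc2)S(=O)(=O)Cc2ccc(F)cc2)cc1OC` gives 50000 nM, and the change from compound 3 to compound 1, ((4-fluorobenzyl)sulfonyl in place of (4-fluorobenzyl)sulfanyl on a double-bonded chain carbon bound to a carbonyl carbon and a double-bonded chain carbon), produced a 50-fold higher number from compound 3 to compound 1 (1.70 log units; beyond the scatter). Compound 2 `COc1cc(OC)c(/C=C(/SCc2ccc(F)cc2)C(=O)c2ccc(Cl)cc2)c(OC)c1` gives 10000 nM; how its core differs from that of compound 3 is not broken down here, so only the two values can be compared.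

Compound 4 `COc1cc(OC)c(/C=C(\C(=O)c2ccc(Cl)cc2)S(=O)(=O)Cc2ccc(F)cc2)c(OC)c1` has not been measured. It arises from compound 2 by the same change, ((4-fluorobenzyl)sulfonyl in place of (4-fluorobenzyl)sulfanyl on a double-bonded chain carbon bound to a carbonyl carbon and a double-bonded chain carbon), made on the same place. Because compound 3 to compound 1 showed a 50-fold higher number from compound 3 to compound 1 (1.70 log units; beyond the scatter), and compound 2 starts from 10000 nM, a weakening of similar size is expected. Compound 4 is expected to show a step of a 10-fold higher number from compound 2 to compound 4 (1.00 log units; beyond the scatter) in this assay. The estimate for compound 4 is 100000 nM, within a range from 20000 nM to 500000 nM.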

Compound 4, concentration for 50% growth inhibition: 25000 nM
Beside the measured number, compound 4's estimate is 4.0-fold (0.60 log units) above it; measured number inside the range.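

In this assay, placing (4-fluorobenzyl)sulfonyl in place of (4-fluorobenzyl)sulfanyl gave a 2.5-fold higher number from compound 2 to compound 4 (0.40 log units; beyond the scatter), so growth inhibition weakened on this core as it did on the core of compound 3, but the size of the step did not carry over: the same change on two cores in this assay, a 50-fold higher number (1.70 log units; beyond the scatter) from compound 3 to compound 1 and a 2.5-fold higher number (0.40 log units; beyond the scatter) from compound 2 to compound 4, 20-fold (1.30 log units) apart, beyond the scatter of two such steps

The direction of the change therefore held on both cores shown, while its size depended on the core it was made on, so a step measured on one core gave a poor guide to the size of the step on the other. These two pairs do not show which feature of the cores sets the size of the step, nor do they establish a rule for other cores in the series.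

The compounds shown leave open how a sulfinyl group would behave at the same place on either core. They also leave open whether the direction of the step would hold on a core carrying an amine or a carboxylic acid on the second aryl ring.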